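Swapping one end group on a weak growth inhibitor

This account rests on a few compounds, and the source may have more. Where it says the series, first, only, none or still open, it means among the compounds named here.

compound 1 `CCN1CCN(Cc2ccc(NC(=O)Nc3ccc(Oc4cc(NC(C)=O)ncn4)cc3)cc2C(F)(F)F)CC1` gives 38 nM
compound 2 `CC(=O)Nc1cc(Oc2ccc(NC(=O)Nc3ccc(C)c(C(F)(F)F)c3)cc2)ncn1` gives 3230 nM
compound 3 `Cc1ccc(NC(=O)Nc2ccc(Oc3cc(/N=C/N(C)C)ncn3)cc2)cc1C(F)(F)F` gives 6610 nM

In a functional assay on BaF3 cells (Mus musculus) for inhibition, read by CCK-8 assay, with a stated time of 72 h (a higher number here means a weaker inhibitor of growth, a lower number a stronger inhibitor of growth), compound 3 sits at the weak end. Here compound 3 gives 6610 nM, the highest number of the three, and its distance to each of the others lies beyond the scatter. The unmeasured compound 4 `CCC(=O)Nc1cc(Oc2ccc(NC(=O)Nc3ccc(C)c(C(F)(F)F)c3)cc2)ncn1` alters one group of compound 3 on an aromatic carbon: a group of 5 heavy atoms (3 carbon, 1 nitrogen, 1 oxygen; no ring) in place of a group of 5 heavy atoms (3 carbon, 2 nitrogen; no ring), on an aromatic carbon. The incoming group is propanoylamino.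

Among the measured compounds shown here, two measured steps bear on this change. The closer one, on the same aromatic carbon, is modest: a 2.0-fold higher number from compound 2 to compound 3 (0.31 log units; beyond the scatter). In that step, the group now leaving replaced a group that, like propanoylamino, holds an oxygen. The other step is large: an 85-fold higher number from compound 1 to compound 2 (1.93 log units; beyond the scatter). It lies elsewhere, on a saturated chain carbon, where compound 4 carries the same hydrogen as compound 2, so no gain of that size is expected.

What remains is the expectation of a modest step to a lower number in this assay, toward the 3230 nM of compound 2. The expected change is a 2.2-fold lower number from compound 3 to compound 4 (0.34 log units; beyond the scatter). For compound 4 the estimate is 3000 nM, with an expected range from 1200 nM to 7500 nM.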

Compound 4, concentration for 50% growth inhibition: 990 nM
For compound 4 the middle estimate is 3.0-fold (0.48 log units) above the measured one; the whole stated range lies above it.
By their numbers in this assay, from the lowest: compound 1; then compound 4; then compound 2; then compound 3.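

In this assay, among the compounds shown here, the group on this aromatic carbon of the six-membered ring with 2 nitrogen has more influence than the earlier compounds suggested: putting propanoylamino in place of the group of compound 3 gives a 6.7-fold lower number from compound 3 to compound 4 (0.82 log units; beyond the scatter), a bigger change than a 2.0-fold higher number from compound 2 to compound 3 (0.31 log units; beyond the scatter). The new compound also shows that a small edit within the amide chain registers in this assay: a single added methyl gives a 3.3-fold lower number from compound 2 to compound 4 (0.51 log units; beyond the scatter), so the two amides, which differ only by that methyl, cannot be treated as interchangeable. No measurement shown here explains why either step goes the way it does.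

For the compounds shown here, two amide chains give only one step, so it remains open whether a longer chain such as butanoylamino would move the number further in the same direction, or reverse it, and how a plain amine on this carbon would compare. From the compounds shown here alone, it is also open whether the methyl's gain would carry over to a compound bearing the 4-ethylpiperazin-1-yl group of compound 1, which already gives 38 nM.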